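A few compounds are considered here, and "the series" means these few. Any claim that something is new, unique, unknown or untested is made for them only; others in the source may bear on it.

Compound 3, `Cc1nnc(-c2cccc(-c3ccc(C(=O)N(Cc4cccc(OCCCCCC(=O)O)c4)C(C)C)cc3)c2)o1`, is one of three compounds tested for cytotoxicity in an ADME assay on BJ cells (Homo sapiens) for cytotoxicity, read by CellTiter-Glo and resazurin assay, with a stated time of 72 h; a lower number here means that less compound is needed, a higher number that more compound is needed for the effect. In this assay compound 3 gives only a limit, > 26000 nM, which marks the top of the tested range rather than a measured number. The same holds for compound 1, `CC(C)N(Cc1cccc(OCCCCCC(=O)O)c1)C(=O)c1ccc(-c2ccncc2)cc1`, whose result in this assay is the limit > 26000 nM. Compound 2, `CC(C)N(Cc1cccc(OCCCCCC(=O)O)c1)C(=O)c1ccc(-c2ccco2)cc1`, likewise reaches only the limit > 26000 nM in this assay. Because all three sit at the limit of > 26000 nM in this assay, at which 3 of the 3 values shown sit, the steps between them cannot be sized: a step that the two limits leave unreadable from compound 1 to compound 3, a step that the two limits leave unreadable from compound 2 to compound 3 and a step that the two limits leave unreadable from compound 1 to compound 2 all remain unreadable.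

Compound 4, `CCOc1cccc(-c2ccc(C(=O)N(Cc3cccc(OCCCCCC(=O)O)c3)C(C)C)cc2)c1`, differs from compound 3 by one change: ethoxy in place of 5-methyl-1,3,4-oxadiazol-2-yl on an aromatic carbon. Within the data shown here, none of the measured steps gives a readable size, so they offer no direction for this assay; they only show that three different groups in this position all left the compounds without measurable cytotoxicity. Compound 4 is therefore expected to behave like its neighbours, with an estimated 26000 nM and a range from 13000 nM to 60000 nM, meaning an expected step of a number no higher from compound 3 to compound 4 (the limit leaves the size open) that most likely again ends at the limit.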

Compound 4, half-maximal effective concentration: > 20800 nM
Compound 4 was reported as a limit; the forecaster's own chance of this, stated with the estimate: 85%; the middle value lies beyond the limit too.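

In this assay compound 4 gives only a limit, > 20800 nM. Among these compounds, compound 1, compound 2 and compound 3 also give only limits, so no step to compound 4 can be read. The compounds shown leave open what concentration any of the four would need for the effect, and whether exchanging these groups changes it at all.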